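The source may hold more compounds than are shown below. What is called first, only, known or untested is meant among the compounds shown, and "the series" means these compounds.

Measured in an ADME assay on cells for inhibition of cytochrome P450 11B1, mitochondrial (Homo sapiens), read by HPLC, with a stated time of 60 min; a lower number here means a stronger inhibitor, a higher number a weaker inhibitor:
compound 1 `CC(C)c1ncncc1-c1nc2cc(F)c(F)cc2n1C1CC1` gives 1910 nM
compound 2 `N#Cc1ncncc1-c1nc2cc(F)c(F)cc2n1C1CC1` gives 4990 nM
compound 3 `Fc1cc2nc(-c3cncnc3NCCC(F)(F)F)n(C3CC3)c2cc1F` gives 378 nM

Compound 3 has the lowest number of the three; the steps of a 5.1-fold lower number from compound 1 to compound 3 (0.70 log units; beyond the scatter) and a 13-fold lower number from compound 2 to compound 3 (1.12 log units; beyond the scatter) both lie beyond the scatter, so it stands as the strongest inhibitor shown. Compound 4 `Fc1cc2nc(-c3cncnc3C(F)F)n(C3CC3)c2cc1F` differs from compound 3 in one place: difluoromethyl in place of (3,3,3-trifluoropropyl)amino on an aromatic carbon. Among the measured compounds shown here, no measured step covers this exchange directly. The bearing steps are those at the same aromatic carbon: a 5.1-fold lower number from compound 1 to compound 3 (0.70 log units; beyond the scatter) and a 13-fold lower number from compound 2 to compound 3 (1.12 log units; beyond the scatter) show that replacing the (3,3,3-trifluoropropyl)amino group by isopropyl or cyano raises the number, while a 2.6-fold higher number from compound 1 to compound 2 (0.42 log units; beyond the scatter) shows those two alternatives differ only modestly from each other. A higher number is therefore expected for compound 4, of a size near those steps, a 4.0-fold higher number from compound 3 to compound 4 (0.60 log units; beyond the scatter). Compound 4 is estimated at 1500 nM, with a range of 500 nM to 4500 nM.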

Compound 4, half-maximal inhibitory concentration: 4330 nM
Beside the measured number, compound 4's estimate is 2.9-fold (0.46 log units) below it; the range from low to high includes it.
By their numbers in this assay, from the lowest: compound 3; then compound 1; then compounds 4 and 2 (each within the scatter of the next).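

In this assay, difluoromethyl on this aromatic carbon does not keep the gain seen with (3,3,3-trifluoropropyl)amino (an 11-fold higher number from compound 3 to compound 4 (1.06 log units; beyond the scatter)). It cannot be told apart from cyano (a 1.2-fold lower number from compound 2 to compound 4 (0.06 log units; within the scatter)) and gives a weaker inhibitor than isopropyl (a 2.3-fold higher number from compound 1 to compound 4 (0.36 log units; beyond the scatter)). Among these four groups, only (3,3,3-trifluoropropyl)amino gives a number clearly lower than the others.

From the compounds shown here alone, whether the gain follows the amine nitrogen or the fluorinated chain stays open, and a plain propylamino or a 3,3,3-trifluoropropyl chain joined through carbon would separate the two. Nothing available explains these steps.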